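Swapping the ethynyl of compound 1 for a phenyl

This account rests on a few compounds, and the source may have more. Where it says the series, first, only, none or still open, it means among the compounds named here.

Of the compounds shown here, two sharing one core have been measured. Compound 1 `C#CCNCc1cc2ccccc2n1C` gives 3830 nM in an assay on isolated protein for inhibition of Amine oxidase [flavin-containing] B (Rattus norvegicus) (a lower number here means a stronger inhibitor, a higher number a weaker inhibitor), which is the higher of the two numbers, so compound 1 is the weaker of the pair. Compound 2 `C#CCNCc1cc2cc(OC)ccc2n1C` gives 4 nM in this assay, and the step of a 960-fold lower number from compound 1 to compound 2 (2.98 log units; beyond the scatter) comes from a methoxy in place of hydrogen on an aromatic carbon.

Compound 3 `Cn1c(CNCc2ccccc2)cc2ccccc21` has not been measured. It differs from compound 1 by phenyl in place of ethynyl on a saturated chain carbon bound to an amine nitrogen: the ethynyl on the chain beside the amine nitrogen leaves and a phenyl enters there. Within the data shown here, none of the measured steps bears on this change, since the only step seen alters the aromatic ring, not the chain carbon bound to the amine nitrogen. Among the measured compounds shown here, with no step to lean on, the direction and size in this assay are open, and the estimate for compound 3 is simply kept near compound 1 with a wide range.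

Compound 3 is thus expected to give about 12000 nM in this assay, between 2500 nM and 80000 nM, which would mean the expected step of a 3.1-fold higher number from compound 1 to compound 3 (0.50 log units; beyond the scatter).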

Compound 3, inhibition constant: 48000 nM
Beside the measured number, compound 3's estimate is 4.0-fold (0.60 log units) below it; the measured number falls inside the stated range.
By their numbers in this assay, from the lowest: compound 2; then compound 1; then compound 3.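

In this assay, the saturated chain carbon bound to an amine nitrogen proves sensitive to what it carries: phenyl in place of ethynyl gives a 13-fold higher number from compound 1 to compound 3 (1.10 log units; beyond the scatter) and moves the number in the weaker direction. Among these compounds, the earlier step concerned only the aromatic ring, so this is the first sign that the chain end matters too. The swap removes a triple bond and replaces 2 heavy atoms with 6 in a ring, and because these differences arrive together, this one pair cannot show which of them counts, while no measurement shown here explains the rise.

As far as these compounds go, it remains open whether a methyl, a cyclohexyl or a longer chain ending in ethynyl at this place would stay close to compound 1 or lose as much as the phenyl does. Also unresolved is whether the same swap would cost as much on the methoxy-bearing compound 2 , which stands at 4 nM, since the effects of the two changes may not simply add up.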